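From Pyridinyl to Propylphenyl: Expected Inhibition of Compound 4

The source may report more compounds than this note shows. Statements on the series, on what has been measured and on what is new or still open speak of the compounds shown alone.

compound 1 `O=C1CCC(N2C(=O)c3ccc(Nc4ccccn4)cc3C2=O)C(=O)N1`: 9%
compound 2 `O=C1CCC(N2C(=O)c3cccc(Nc4ccccc4)c3C2=O)C(=O)N1`: 4%
compound 3 `C=C(OCC)c1ccc(Nc2cccc3c2C(=O)N(C2CCC(=O)NC2=O)C3=O)cc1`: 10%

In an assay on FRT-Jurkat cells for inhibition of nuclear factor NF-kappa-B complex (Homo sapiens), read by flow cytometry, with a stated time of 24 h, tested at 10 uM (on this read-out higher numbers stand for more inhibition at the one concentration tested (going by the name of the read-out) and lower numbers for less inhibition), compound 1 gives 9%. Among the three measured compounds its value is the second highest, yet the nearest value, that of compound 3, and the furthest, that of compound 2, both lie within the usual scatter of it, so the three compounds cannot be told apart on this read-out.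

Compound 4 `CCCc1ccc(Nc2ccc3c(c2)C(=O)N(C2CCC(=O)NC2=O)C3=O)cc1` differs from compound 1 in one place: 4-propylphenyl in place of pyridin-2-yl on a nitrogen on an aromatic ring. Going by the values given here, the single measured step, a number 6 percentage points higher from compound 2 to compound 3 (within the scatter), replaces a hydrogen on an aromatic carbon, not the ring attached to the nitrogen, so it bears on the present change only indirectly; it shows that a substantial addition to a phenyl ring left the read-out within the scatter. With every measured value low and every measured step within the scatter, no movement beyond the scatter is expected for compound 4, and the estimated step is a number 1 percentage points higher from compound 1 to compound 4 (within the scatter). Compound 4 is therefore expected to give about 10%, within a range from -5% to 30%.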

Compound 4, a percentage reported as inhibition, at one concentration (the size of the read-out at that concentration, not a potency): 10%
Compound 4: the middle estimate sits on the measured number at the digits printed; the measured number falls inside the stated range.
By their numbers in this assay, from the lowest: compounds 2, 1, 3 and 4 (each within the scatter of the next).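

In this assay, putting 4-propylphenyl in place of pyridin-2-yl on a nitrogen on an aromatic ring gives a number 1 percentage points higher from compound 1 to compound 4 (within the scatter), the first step read at this place rather than on a ring carbon. It shows that this read-out does not separate an all-carbon aromatic ring bearing a propyl chain from an aromatic ring with one hetero atom, so this exchange alone does not lift the inhibition beyond the scatter. No supporting data bear on why the number holds.

As far as these compounds go, it remains open whether any group at this place can move the number beyond the scatter, for instance a carboxylic acid, an amine or a longer chain on the phenyl ring. A single-concentration percentage also leaves the potency of compound 4 undefined.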